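From an Amine to an Amide on the Chain

The compounds below may be only part of what the source reports. "The series", "measured", "known", "first", "only" and "open" are said of these compounds alone.

Compound 1 `Cn1nc(-c2cccnc2)c2ccccc2c1=O` gives 63% in an assay on isolated protein (Oryctolagus cuniculus) with Thromboxane-A synthase (Homo sapiens) as the target, tested at 1 uM; a higher number here means more inhibition at the concentration tested (going by the name of the read-out), a lower number less inhibition.
Compound 2 `NCCn1nc(-c2cccnc2)c2ccccc2c1=O` gives 29% in this assay.

Compound 2 stands lowest of the two measured compounds. Its nearest neighbour is compound 1, and the step of a number 34 percentage points lower from compound 1 to compound 2 (beyond the scatter), brought by aminomethyl in place of hydrogen on a saturated chain carbon bound to an aromatic nitrogen, lies well beyond the scatter.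

Compound 3 `CC(C)NC(=O)CCCn1nc(-c2cccnc2)c2ccccc2c1=O` has not yet been tested. It differs from compound 2 by (isopropylcarbamoyl)methyl in place of amino on a saturated chain carbon, two bonds along the chain from an aromatic nitrogen. For the measured compounds named here, no measured step bears directly on this exchange: the single step on record, a number 34 percentage points lower from compound 1 to compound 2 (beyond the scatter), concerns a different change at the same chain and offers only a loose guide. The expectation for this assay is therefore uncertain, and the step estimated is a number 11 percentage points higher from compound 2 to compound 3 (beyond the scatter). Compound 3 is expected to give about 40%, within a range from 15% to 70%.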

Compound 3, a percentage reported as inhibition, at one concentration (the size of the read-out at that concentration, not a potency): 89%
Beside the measured number, compound 3's estimate is 49 percentage points below it; the measured number lies above the stated range.
By their numbers in this assay, from the lowest: compound 2; then compound 1; then compound 3.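

In this assay, a chain at this position is not harmful in itself: 2-(isopropylcarbamoyl)ethyl in place of hydrogen gives a number 26 percentage points higher from compound 1 to compound 3 (beyond the scatter) and lifts the number above that of the compound with the smaller substituent. What the chain carries therefore matters a great deal, as (isopropylcarbamoyl)methyl in place of amino gives a number 60 percentage points higher from compound 2 to compound 3 (beyond the scatter) on the same saturated chain carbon. The measurements offer no explanation for this difference between the amino and isopropylcarbamoyl chains.

As far as these compounds go, the exchange alters both the chain length and its end group, so the share of each remains open. A shorter chain ending in the same isopropylcarbamoyl group, or the present chain ending in a carboxylic acid or an amine, would help to separate the two.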